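The compounds below may be only part of what the source reports. "The series", "measured", "known", "first", "only" and "open" are said of these compounds alone.

Solubility is an early check on whether a compound can stay dissolved well enough to be tested reliably. In a physicochemical assay for solubility, in phosphate buffer, measured as kinetic solubility, at pH 7.4 (on this read-out higher numbers stand for higher solubility and lower numbers for lower solubility), compound 1 `Cc1oc(-c2c(Cl)cccc2Cl)nc1CN1CCC(C(=O)NCCCN2C[C@H](C)C[C@H](C)C2)CC1` gives > 77 ug/mL, which is a limit and not a number. In this assay compound 2 `Cc1ccccc1-c1nc(CN2CCC(C(=O)N3CCN(CCN(C)C)CC3)CC2)c(C)o1` gives > 67 ug/mL, and this too is a limit. Among the compounds with values here, these two results therefore set no order between the compounds, and compound 1 has no exact value to serve as a starting point.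

The next compound to be measured is compound 3 `Cc1cccc(-c2nc(CN3CCC(C(=O)NCCCN4C[C@H](C)C[C@H](C)C4)CC3)c(C)o2)c1`. It keeps the rest of compound 1 and changes one group, with 3-methylphenyl in place of 2,6-dichlorophenyl on an aromatic carbon. Within the data shown here, no measured pair shows what this swap does, so the expectation remains cautious. The estimated step, an at least 1.1-fold lower number from compound 1 to compound 3 (0.04 log units; that floor lies within the scatter), is expected to stay within the usual scatter, with no direction favoured. Compound 3 may well return a limit too. The expected value for compound 3 is 70 ug/mL, with an estimated range from 45 ug/mL to 75 ug/mL.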

Compound 3, solubility: > 69 ug/mL
Compound 3 was reported as a limit (the forecaster's own chance of this, stated with the estimate: 80%); the middle value lies beyond the limit too.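

In this assay, compound 3 gives a limit and not a number, as compound 1 does, so no step can be read between compound 1 and compound 3. Going by these compounds, what 3-methylphenyl in place of 2,6-dichlorophenyl does to solubility stays open, as do the exact values of compound 1, compound 2 and compound 3.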